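Methoxy on the benzylidene arm of a thiosemicarbazone

The source may report more compounds than this note shows. Statements on the series, on what has been measured and on what is new or still open speak of the compounds shown alone.

Measured compounds:
Compound 1 `CC1=CC[C@H](C(C)(C)N=C=S)CC1` in a functional assay on NCI/ADR-RES cells (Homo sapiens) for inhibition, read by sulforhodamine B assay, with a stated time of 48 h (on this read-out lower numbers stand for stronger inhibition of growth and higher numbers for weaker inhibition of growth), gives > 100000 nM, a limit of the assay.
Compound 2 `CC1=CC[C@H](C(C)(C)NC(=S)N/N=C/c2ccccc2)CC1` in this assay gives > 100000 nM, also a limit of the assay.

Compound 2 thus stands where every shown value stands, at the limit of > 100000 nM in this assay, at which 2 of the 2 values shown sit; no numerical potency is known for it, and the same holds for compound 1. Compound 3 `COc1ccc(/C=N/NC(=S)NC(C)(C)[C@H]2CC=C(C)CC2)cc1` carries methoxy in place of hydrogen on an aromatic carbon, so the phenyl of compound 2 becomes a 4-methoxyphenyl. Among the compounds with values here, no step between measured compounds exists here, so nothing indicates how far this change moves the read-out. Since compound 2 shows only a limit at > 100000 nM, the step of a number no higher from compound 2 to compound 3 (the limit leaves the size open) is expected to be none beyond the scatter, with the most likely outcome that compound 3 again reaches only the limit. Compound 3 is therefore estimated at 100000 nM, with a range from 40000 nM to 100000 nM.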

Compound 3, concentration for total growth inhibition: 50400 nM
The estimate for compound 3 lay 2.0-fold (0.30 log units) above the measured number, and the stated range covers the measured number.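

In this assay, within the data shown here, compound 3 gives 50400 nM, the only number in the set so far, so this place on the benzylidene arm is one where a single change can yield a measurable value. Read against compound 2, the change from phenyl to 4-methoxyphenyl is an at least 1.9-fold lower number from compound 2 to compound 3 (0.29 log units; that floor lies within the scatter); that figure is only a floor, and the real step may be larger. The other two compounds give no number to compare with: the limit of > 100000 nM in this assay, at which 2 of the 3 values shown sit.

The compounds shown leave open whether this value is particular to methoxy or would also appear with another group at this place, such as hydroxyl, chlorine or dimethylamino. They also leave open whether a longer chain on the oxygen, such as ethoxy or propoxy, would give a lower number.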